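The compounds below may be only part of what the source reports. "The series", "measured", "known", "first", "only" and "open" are said of these compounds alone.

Measured compounds in a functional assay on HEK293 cells for agonist activity at Glucose-dependent insulinotropic receptor (Homo sapiens), read by cAMP accumulation, with a stated time of 30 min; on this read-out higher numbers stand for an effect only at larger amounts of compound and lower numbers for an effect already at smaller amounts: compound 1 `COc1cc2c(c(Oc3cccc(NS(=O)(=O)c4ccc(Cl)cc4)c3)n1)C(=O)N(C1CC1)C2=O` gives 19 nM; compound 2 `Cc1cc2c(c(Oc3cccc(NS(=O)(=O)c4ccc(Cl)cc4)c3)n1)C(=O)N(C1CC1)C2=O` gives 15 nM; compound 3 `Cc1cc2c(c(Oc3cccc(NS(=O)(=O)c4ccc(Cl)cc4)c3)n1)C(=O)NC2=O` gives 121 nM.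

Compound 3 stands highest of the three, beyond the scatter from both compound 1 and compound 2. Compound 4 `Cc1cc2c(c(Oc3cccc(NS(=O)(=O)c4ccc(Cl)cc4)c3)n1)C(=O)N(C)C2=O` differs from compound 3 by methyl in place of hydrogen on an amide-type nitrogen in a ring. For the measured compounds named here, one measured step bears on this position: an 8.1-fold higher number from compound 2 to compound 3 (0.91 log units; beyond the scatter), which removed a cyclopropyl from the same nitrogen; the step between compound 1 and compound 2 concerns another position and does not inform it. Restoring an alkyl group there, now a methyl rather than a cyclopropyl, is expected to reverse much of that move, giving a lower number in this assay of about a 4.0-fold lower number from compound 3 to compound 4 (0.61 log units; beyond the scatter). For compound 4 the estimate is 30 nM, expected between 10 nM and 90 nM.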

Compound 4, half-maximal effective concentration: 23 nM
Compound 4: the middle estimate sits 1.3-fold (0.12 log units) above what was measured; measured number inside the range.
By their numbers in this assay, from the lowest: compounds 2, 1 and 4 (each within the scatter of the next); then compound 3.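

In this assay a single methyl on the amide-type nitrogen in a ring recovers most of what the bare nitrogen lost, with a 5.3-fold lower number from compound 3 to compound 4 (0.72 log units; beyond the scatter). Methyl and cyclopropyl are not told apart at this position, with a 1.5-fold higher number from compound 2 to compound 4 (0.19 log units; within the scatter), so what counts in these compounds is hydrogen against either group, and the cyclopropyl ring is not required. No data at hand explain this effect. Still open, on these data alone, is whether a longer chain such as n-butyl, or a chain ending in an amine or a carboxylic acid, would be tolerated on this nitrogen.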